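From Nitrile to Methylcarbamoyl on the Amide Nitrogen

The source may hold more compounds than are shown below. What is called first, only, known or untested is meant among the compounds shown, and "the series" means these compounds.

Compound 1 `CC(=O)Nc1ccc(NC(=O)c2cn(Cc3c(F)cccc3F)c3ccc(=O)[nH]c3c2=O)cc1`: 24 nM
Compound 2 `N#Cc1cccc(NC(=O)c2cn(Cc3c(F)cccc3F)c3ccc(=O)[nH]c3c2=O)c1`: 1070 nM

In an in vitro assay on Sf21 cells for inhibition of high affinity 3',5'-cyclic-AMP phosphodiesterase 7A (Homo sapiens), read by scintillation proximity assay, with a stated time of 30 min (on this read-out higher numbers stand for weaker inhibition and lower numbers for stronger inhibition), compound 2 stands highest of the two numbers; its nearest neighbour is compound 1. For the measured compounds named here, the single measured step that bears here is a 45-fold higher number from compound 1 to compound 2 (1.65 log units; beyond the scatter), a large one. Compound 3 `CNC(=O)c1ccc(NC(=O)c2cn(Cc3c(F)cccc3F)c3ccc(=O)[nH]c3c2=O)cc1` differs from compound 2 by 4-(methylcarbamoyl)phenyl in place of 3-cyanophenyl on an amide-type nitrogen. The entering group, like the 4-acetamidophenyl of compound 1, brings one hydrogen-bond donor and one acceptor, so a large move back towards compound 1 is expected. Compound 3 is estimated at 60 nM, in the range 15 nM to 300 nM. The expected step is an 18-fold lower number from compound 2 to compound 3 (1.25 log units; beyond the scatter).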

Compound 3, half-maximal inhibitory concentration: 29 nM
For compound 3 the middle estimate is 2.1-fold (0.32 log units) above the measured one; measured number inside the range.
By their numbers in this assay, from the lowest: compounds 1 and 3 (each within the scatter of the next); then compound 2.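

In this assay, a 37-fold lower number from compound 2 to compound 3 (1.57 log units; beyond the scatter) shows that the large loss seen with 3-cyanophenyl is not fixed to this amide-type nitrogen. a 1.2-fold higher number from compound 1 to compound 3 (0.08 log units; within the scatter) shows that methylcarbamoyl and acetamido on an aromatic carbon cannot be told apart here, so the amide may run in either direction. No measured evidence accounts for these numbers. The step from the nitrile changes both group and ring place at once, so a 4-cyanophenyl would be needed to separate them. Going by these compounds, whether a carboxylic acid or a primary amine could stand in for either amide also remains open.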